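Removing the chloro group: what happens to compound 4?

The source may hold more compounds than are shown below. What is called first, only, known or untested is meant among the compounds shown, and "the series" means these compounds.

In an ADME assay on a cell-free system (plasma, Rattus norvegicus) for metabolic stability, read by LC-MS, with a stated time of 60 min, tested at 100 uM (on this read-out higher numbers stand for a more stable compound and lower numbers for a less stable compound), compound 3 `Cc1c(OCCCCOc2ccc(C(=O)O)cc2Cl)ccc(C(=O)CC2CCCC2)c1O` gives 120%, the highest of three numbers. Compound 1 `Cc1c(OCCCCOCOc2ccc(C(=O)O)cc2)ccc(C(=O)CC2CCCC2)c1O` gives 100% and compound 2 `Cc1c(OCCCCOc2ccc(C(=O)O)cc2F)ccc(C(=O)CC2CCCC2)c1O` gives 97%, two values within the scatter of each other. Compound 4 `Cc1c(OCCCCOc2cccc(C(=O)O)c2)ccc(C(=O)CC2CCCC2)c1O` has not been measured yet. Its difference from compound 3 is 3-carboxyphenyl in place of 4-carboxy-2-chlorophenyl on an oxygen on a saturated carbon. In words, 3-carboxyphenyl stands in place of 4-carboxy-2-chlorophenyl on an oxygen on a saturated carbon.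

Going by the values given here, two measured steps bear on this, and both are modest and beyond the scatter: a number 23 percentage points higher from compound 2 to compound 3 (beyond the scatter) for chloro in place of fluoro, and a number 20 percentage points higher from compound 1 to compound 3 (beyond the scatter) for the change of the whole group. The remaining step, a number 3 percentage points lower from compound 1 to compound 2 (within the scatter), stays within the scatter. Compound 3 alone carries chloro, and compound 4 loses it, so a return towards the two lower values seems likely. Among the compounds with values here, no measured compound carries 3-carboxyphenyl, so that part of the change remains untested. A modest fall is therefore expected, a number 20 percentage points lower from compound 3 to compound 4 (beyond the scatter). Compound 4 is estimated at 100%, within an expected range from 84% to 118%.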

Compound 4, percent of the compound remaining: 99%
The estimate for compound 4 lay 1 percentage points above the measured number; the measured number falls inside the stated range.
By their numbers in this assay, from the lowest: compounds 2, 4 and 1 (each within the scatter of the next); then compound 3.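

In this assay the picture sharpens: a number 21 percentage points lower from compound 3 to compound 4 (beyond the scatter) sets compound 3 apart, whereas a number 2 percentage points higher from compound 2 to compound 4 (within the scatter) and a number 1 percentage points lower from compound 1 to compound 4 (within the scatter) both stay within the scatter. Going by these compounds alone, at this place, on an oxygen on a saturated carbon, 3-carboxyphenyl therefore groups with 4-carboxy-2-fluorophenyl and the (4-carboxyphenoxy)methyl group, leaving 4-carboxy-2-chlorophenyl as the only group that stands out among the four compounds. No measurement is available that could explain this difference.

Compound 4 loses the chloro group and also carries its carboxylic acid at a different ring position, so these compounds cannot show which of the two changes accounts for the step. A plain 4-carboxyphenyl group would separate those two changes, and a 4-carboxy-2-bromophenyl group would show whether the higher number extends beyond chloro.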